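The source may report more compounds than this note shows. Statements on the series, on what has been measured and on what is new or still open speak of the compounds shown alone.

In a functional assay on DU-145 cells (Homo sapiens) for inhibition, read by MTT assay, with stated times of 18 h and 4 h (on this read-out lower numbers stand for stronger inhibition and higher numbers for weaker inhibition), compound 1 `CCCCCCCCCCOP(=O)(O)OCCSC(=S)N1CCCC1` gives 46100 nM, compound 3 `CCCCCCCCCCOP(=O)(O)OCCSC(=S)N1CCCCC1` gives 29300 nM and compound 2 `CCCCCCCCCCOP(=O)(O)OCCSC(=S)N1CCN(C)CC1` gives 82300 nM. Compound 2 thus sits at the high end, within the scatter of compound 1 and beyond it only against compound 3. Compound 4 `CCCCCCOP(=O)(O)OCCSC(=S)N1CCN(C)CC1` keeps the 4-methylpiperazin-1-yl group of compound 2 but has a shorter chain: hydrogen in place of butyl on a saturated chain carbon, six bonds along the chain from an oxygen on an unsaturated carbon. The measured steps change only the group on the thiocarbonyl carbon: a 1.8-fold higher number from compound 1 to compound 2 (0.25 log units; within the scatter), a 1.6-fold lower number from compound 1 to compound 3 (0.20 log units; within the scatter) and, modestly, a 2.8-fold lower number from compound 2 to compound 3 (0.45 log units; beyond the scatter). None touches the chain, so they guide this change only loosely. A higher number is expected, with the estimated step being a 2.2-fold higher number from compound 2 to compound 4 (0.34 log units; beyond the scatter). For compound 4 the expected value is 180000 nM, with an estimated range of 80000 nM to 450000 nM.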

Compound 4, half-maximal inhibitory concentration: > 100000 nM
Compound 4: only a limit was reported (the forecaster's own chance of this, stated with the estimate: 30%); the middle value is on the limit's open side.
By their numbers in this assay, from the lowest: compounds 3, 1 and 2 (each within the scatter of the next, the first and the last beyond it). At a limit, above all of these: compound 4.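

Compound 4 is known only by a limit: the limit of > 100000 nM in this assay, at which 1 of the 4 values shown sits. This is the first change shown in the chain rather than in the group on the thiocarbonyl carbon, and it gives an at least 1.2-fold higher number from compound 2 to compound 4 (0.08 log units; that floor lies within the scatter). Going by these compounds, removing butyl at this place brings no lower number, but the floor alone does not establish a real rise, and the true size of the step stays unknown.

On these data alone, it remains open whether the same shortening would behave alike with the pyrrolidin-1-yl group of compound 1 or the piperidin-1-yl group of compound 3. Also open, as far as these compounds go, is what an octyl chain or a longer dodecyl chain would give.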